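This account rests on a few compounds, and the source may have more. Where it says the series, first, only, none or still open, it means among the compounds named here.

Two close relatives have been measured so far. In a functional assay on HeLa cells (Homo sapiens) for inhibition, read by trypan blue exclusion, with a stated time of 72 h (a higher number here means a weaker inhibitor of growth, a lower number a stronger inhibitor of growth), compound 1 (`CC/C(=C(/c1ccccc1)c1ccc(NC(=O)C(C)C)cc1)c1ccccc1`) gives 28100 nM, the higher of the two numbers, and compound 2 (`CC/C(=C(\c1ccc(NC(=O)C(C)C)cc1)c1ccc(OC)cc1)c1ccccc1`) gives 10100 nM. Compound 1 is therefore the weaker growth inhibitor of the pair, and the gap between them lies beyond the usual scatter.

The next compound is compound 3 (`CC/C(=C(/c1ccccc1)c1ccc(NC(=O)C(C)C)cc1)c1ccc(O)cc1`). Its change from compound 1 is hydroxy in place of hydrogen on an aromatic carbon, turning a phenyl into a 4-hydroxyphenyl.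

Within the data shown here, only one measured step bears on this change, a 2.8-fold lower number from compound 1 to compound 2 (0.44 log units; beyond the scatter), a modest shift that came from putting methoxy in place of hydrogen on an aromatic carbon. Among the measured compounds shown here, that step is the sole guide, since it also adds a single oxygen-linked group to an aromatic carbon. However, methoxy is not hydroxy, and no hydroxy compound has been measured yet. A modest step toward a lower number in this assay is the best expectation, with real uncertainty around it.

The expected change is a 2.6-fold lower number from compound 1 to compound 3 (0.41 log units; beyond the scatter). For compound 3 the estimated value is 11000 nM, with an expected range of 4000 nM to 28000 nM.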

Compound 3, concentration for 50% growth inhibition: 5100 nM
The estimate for compound 3 lay 2.2-fold (0.33 log units) above the measured number; the measured number falls inside the stated range.
By their numbers in this assay, from the lowest: compounds 3 and 2 (each within the scatter of the next); then compound 1.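

A single hydroxy, on a different phenyl of the shared core from the methoxy of compound 2, gives a 5.5-fold lower number from compound 1 to compound 3 (0.74 log units; beyond the scatter) in this assay. This shows that the response to substitution is not confined to one ring: phenyl to 4-hydroxyphenyl lowers the number beyond the scatter, and so does the methoxy change on the other ring, which gives a 2.8-fold lower number from compound 1 to compound 2 (0.44 log units; beyond the scatter). Nothing among the data shown explains why the hydroxy change has this effect.

The compounds shown leave open whether the hydroxy itself matters at this position or whether any oxygen-linked group would do: methoxy on this same phenyl would separate those two readings, while an amine or a carboxylic acid in the same place would show how far the trend extends. Also open, from the compounds shown here alone, is whether hydroxy on this ring and methoxy on the other, carried together on the core of compound 1, would lower the number further than either change does alone.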